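Pyrazole for acetamidomethyl-isoxazole at the core of compound 1

This account rests on a few compounds, and the source may have more. Where it says the series, first, only, none or still open, it means among the compounds named here.

Measured compounds:
- compound 1, `CCNC(=O)c1noc(-c2cc(C(C)C)c(O)cc2O)c1-c1cc(CNC(C)=O)no1`: a functional assay on A2780 cells (Homo sapiens) for inhibition; a lower number here means a stronger inhibitor, a higher number a weaker inhibitor "not determined" (no result reported)
- compound 2, `CCCN(CCC)Cc1cc(-c2c(C(=O)NCC)noc2-c2cc(C(C)C)c(O)cc2O)on1`: this assay "not determined" (no result reported)
- compound 3, `CCNC(=O)c1noc(-c2cc(C(C)C)c(O)cc2O)c1-c1cc(CN2CCCC2)no1`: this assay 55 nM

Compound 1 stands without a number in this assay; no result was reported for it, and the same holds for compound 2. Within the data shown here, only compound 3 gives a figure, 55 nM, so the series has a single anchor and no step between two measured compounds from which a size of change could be read.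

Compound 4, `CCNC(=O)c1noc(-c2cc(C(C)C)c(O)cc2O)c1-c1cnn(C)c1`, differs from compound 1 in one place: 1-methyl-1H-pyrazol-4-yl in place of 3-(acetamidomethyl)-1,2-oxazol-5-yl on an aromatic carbon. Among the measured compounds shown here, no step can be computed for this change, since compound 1 itself has no number. What can be said is that compound 4 shares the core and the ethylcarbamoyl group with compound 3, which carries a different group at the same aromatic carbon, and compound 3 sits at 55 nM in this assay.

On that basis compound 4 is expected near the value of compound 3 because compound 3 shows 55 nM, with a wide range to allow for the different group: estimate 120 nM, from 25 nM to 600 nM.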

Compound 4, half-maximal inhibitory concentration: 20 nM
Estimate against measurement, compound 4: 6.0-fold (0.78 log units) above; the whole stated range lies above it.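

No step can be read from compound 1 to compound 4: of the two, only compound 4 has a single number in this assay, 20 nM. The compounds shown leave open what 1-methyl-1H-pyrazol-4-yl in place of 3-(acetamidomethyl)-1,2-oxazol-5-yl changes in this assay. Nothing available explains this result.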